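Methoxycarbonyl to Ethoxycarbonyl on a Shared Core

The compounds below may be only part of what the source reports. "The series", "measured", "known", "first", "only" and "open" are said of these compounds alone.

Compound 1 `O=C(O)CC1CNC(=O)c2cc(Br)c(Br)n21` is a carboxylic acid on the shared core. In a functional assay on A549 cells (Homo sapiens) for cytotoxicity, read by CCK-8 assay, with a stated time of 72 h (on this read-out higher numbers stand for weaker inhibition and lower numbers for stronger inhibition), compound 1 gives only a limit, > 200000 nM. Compound 2 `COC(=O)CC1CNC(=O)c2cc(Br)c(Br)n21` carries methyl in place of hydrogen on an oxygen next to a carbonyl group, and in this assay compound 2 gives 82000 nM, the only actual number shown, since the other result is the limit of > 200000 nM in this assay, at which 1 of the 2 values shown sits. That change brought an at least 2.4-fold lower number from compound 1 to compound 2 (0.38 log units; beyond the scatter).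

Compound 3 `CCOC(=O)CC1CNC(=O)c2cc(Br)c(Br)n21` differs from compound 2 by methyl in place of hydrogen on a saturated chain carbon bound to an oxygen next to a carbonyl group. Within the data shown here, the only measured step, the one from compound 1 to compound 2, acted at a related place but exchanged an acid for an ester, so it offers weak guidance here. A change within the scatter, or a small lowering in this assay, is expected: a 1.4-fold lower number from compound 2 to compound 3 (0.14 log units; within the scatter). Compound 3 is therefore estimated at 60000 nM, between 20000 nM and 180000 nM.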

Compound 3, half-maximal inhibitory concentration: 41000 nM
Estimate against measurement, compound 3: 1.5-fold (0.17 log units) above, and the stated range covers the measured number.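

Going from methoxycarbonyl to ethoxycarbonyl gives a 2.0-fold lower number from compound 2 to compound 3 (0.30 log units; within the scatter) in this assay, so the two esters cannot be told apart at this position. The separation from the carboxylic acid does hold for this second ester: the change from the acid to the ethyl ester gives an at least 4.8-fold lower number from compound 1 to compound 3 (0.68 log units; beyond the scatter), and this step, like the one to the methyl ester, lies beyond the scatter. As far as these compounds go, compound 1 gives only a limit, so the true size of that step stays unknown: the limit of > 200000 nM in this assay, at which 1 of the 3 values shown sits.

The compounds shown leave open whether a longer chain, such as propyl, or a branched one, such as isopropyl, would move the number beyond the scatter. They also leave open how an amide in place of the ester would read out in this assay.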